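The compounds below may be only part of what the source reports. "The series", "measured", "known", "first", "only" and "open" are said of these compounds alone.

Measured compounds:
compound 1, `O=[N+]([O-])c1ccc(S(=O)(=O)NC2=NCCN2C(=S)SN2CCn3c2nsc3=S)cc1`
compound 2, `O=S(=O)(NC1=NCCN1C(=S)SN1CCn2c1nsc2=S)c1ccccc1Cl`
compound 3, `O=S(=O)(NC1=NCCN1C(=S)SN1CCn2c1nsc2=S)c1ccc(Cl)cc1`

In a functional assay on KYSE-510 cells (Homo sapiens) for antiproliferative activity, read by crystal violet staining, with a stated time of 96 h (a lower number here means a stronger inhibitor of growth, a higher number a weaker inhibitor of growth), compound 1 gives >= 20000 nM, a limit of the assay. Compound 2 also gives only a limit, >= 20000 nM. Compound 3 likewise gives >= 20000 nM, a limit. Compound 3 thus stands with the other two at the limit of >= 20000 nM in this assay, at which 3 of the 3 values shown sit, and no measured number separates any of them. The change to compound 4, `O=S(=O)(NC1=NCCN1C(=S)SN1CCn2c1nsc2=S)c1ccc(Cl)c(Cl)c1`, is chloro in place of hydrogen on an aromatic carbon. The steps that alter the same ring, a step that the two limits leave unreadable from compound 1 to compound 3 and a step that the two limits leave unreadable from compound 2 to compound 3, and also a step that the two limits leave unreadable from compound 1 to compound 2, are all unreadable between limits and give no size to work from. A further chloro on a ring that already carries one is expected to leave the read-out at the limit. The expected step of a number no higher from compound 3 to compound 4 (the limit leaves the size open) is therefore nil. Compound 4 is estimated at 20000 nM, within 8000 nM to 60000 nM, most likely reported again as a limit.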

Compound 4, concentration for 50% growth inhibition: >= 20000 nM
Compound 4: a limit, no number (the forecaster's own chance of this, stated with the estimate: 85%); the middle value lies on the limit itself.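

In this assay compound 4 gives >= 20000 nM, a limit, so no step to it from compound 1, compound 2 or compound 3 can be read: the limit of >= 20000 nM in this assay, at which 4 of the 4 values shown sit.

The compounds shown leave open whether any change on the phenyl ring on the sulfonyl sulfur gives a measured number in this assay.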